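The source may report more compounds than this note shows. Statements on the series, on what has been measured and on what is new or still open speak of the compounds shown alone.

In a functional assay on NCI-H460 cells (Homo sapiens) for inhibition, with a stated time of 72 h (a lower number here means a stronger inhibitor, a higher number a weaker inhibitor), compound 1 `COc1ccc(S(=O)(=O)N2CCc3cccc(-c4ccc([N+](=O)[O-])cc4)c32)cc1` gives 53.1 nM and compound 2 `COc1ccc(-c2cccc3c2N(S(=O)(=O)c2ccc(OC)cc2)CC3)cc1` gives 302 nM while compound 3 `COc1ccc(S(=O)(=O)N2CCc3cccc(-c4cccc(F)c4)c32)cc1` gives 167 nM on the same read-out. The numbers show a 1.8-fold lower number from compound 2 to compound 3 (0.26 log units; within the scatter) so that pair is not separated, and they show a 3.1-fold higher number from compound 1 to compound 3 (0.50 log units; beyond the scatter) so compound 3 sits clear of the nitro compound. Next comes compound 4 `COc1ccc(S(=O)(=O)N2CCc3cccc(-c4cccs4)c32)cc1` with the change thiophen-2-yl in place of 3-fluorophenyl on an aromatic carbon in words: thiophen-2-yl in place of 3-fluorophenyl on an aromatic carbon. All measured steps swap the aryl group on this same carbon, the largest being a 5.7-fold higher number from compound 1 to compound 2 (0.75 log units; beyond the scatter) in this small set, yet none brings in a five-membered ring, so they only suggest a likely size. The working guide is compound 3 at 167 nM as the starting value. No step beyond the scatter is expected in this assay and the estimated change is a 1.1-fold lower number from compound 3 to compound 4 (0.05 log units; within the scatter) with no clear direction. For compound 4 the expected value is 150 nM with an estimated range from 60 nM to 380 nM as the working figure.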

Compound 4, half-maximal inhibitory concentration: 229 nM
The estimate for compound 4 lay 1.5-fold (0.18 log units) below the measured number; the measured number falls inside the stated range.
By their numbers in this assay, from the lowest: compound 1; then compounds 3, 4 and 2 (each within the scatter of the next).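

At this aromatic carbon of the shared core, this assay now includes a five-membered aromatic ring with one hetero atom, and thiophen-2-yl is not separated from the six-membered aryl groups, as shown by a 1.4-fold higher number from compound 3 to compound 4 (0.14 log units; within the scatter) and by a 1.3-fold lower number from compound 2 to compound 4 (0.12 log units; within the scatter). The 4-nitrophenyl group of compound 1 still stands apart from this new ring, with a 4.3-fold higher number from compound 1 to compound 4 (0.63 log units; beyond the scatter), so compound 1 keeps the lowest number of the four, now against a ring of a different size as well. No available evidence bears on this result.

The compounds shown leave open whether the gap to compound 1 goes with the nitro group itself or with its place on the phenyl ring. They also leave open how an amine or a carboxylic acid on the aryl ring at this carbon would read out.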